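A few compounds are considered here, and "the series" means these few. Any claim that something is new, unique, unknown or untested is made for them only; others in the source may bear on it.

Compound 1 `CSc1ccc(C2=C(c3ccc(F)c(F)c3)C(=O)N3CCCC3C2)cc1` gives 200 nM in a functional assay on SW-620 cells (Homo sapiens) for cytotoxicity; on this read-out higher numbers stand for weaker inhibition of growth and lower numbers for stronger inhibition of growth. Among the three measured compounds it holds the second highest number: compound 3 `CSc1ccc(C2=C(c3ccc(OCC4CO4)cc3)C(=O)N3CCCC3C2)cc1` gives 90 nM, a lower number, while compound 2 `CSc1ccc(C2=C(c3ccc(O)c(O)c3)C(=O)N3CCCC3C2)cc1` gives 50000 nM. Within the data shown here, the single measured step at the same position, a 250-fold higher number from compound 1 to compound 2 (2.40 log units; beyond the scatter), is a large loss on going to the 3,4-dihydroxyphenyl. Compound 4 `CSc1ccc(C2=C(c3ccc(SC)cc3)C(=O)N3CCCC3C2)cc1` differs from compound 1 by 4-(methylsulfanyl)phenyl in place of 3,4-difluorophenyl on a double-bonded ring carbon; the entering group carries no hydrogen-bond donor, unlike the 3,4-dihydroxyphenyl of compound 2, and compound 3, whose aromatic ring likewise bears no hydroxyl, gives 90 nM. Among the measured compounds shown here, no measured step covers this exact change, so only a modest step is expected in this assay, a 1.3-fold lower number from compound 1 to compound 4 (0.12 log units; within the scatter), quite possibly none beyond the scatter. Compound 4 is estimated at 150 nM, within 40 nM to 600 nM.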

Compound 4, concentration for 50% growth inhibition: 7000 nM
Estimate against measurement, compound 4: 47-fold (1.67 log units) below; the whole stated range lies below it.
By their numbers in this assay, from the lowest: compound 3; then compound 1; then compound 4; then compound 2.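

In this assay, 4-(methylsulfanyl)phenyl gives a 35-fold higher number from compound 1 to compound 4 (1.54 log units; beyond the scatter), and methylsulfanyl in place of (oxiran-2-yl)methoxy gives a 78-fold higher number from compound 3 to compound 4 (1.89 log units; beyond the scatter), so an aromatic ring without hydrogen-bond donors does not by itself keep the number low at this position. Against the 3,4-dihydroxyphenyl, the change gives a 7.1-fold lower number from compound 2 to compound 4 (0.85 log units; beyond the scatter), a modest step that leaves compound 4 well short of compound 1 and compound 3. No supporting data bear on the reason for these steps.

Still open, going by these compounds, is how an amine, a carboxylic acid or a longer ether chain in place of the methylsulfanyl would read in this assay.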